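The source may hold more compounds than are shown below. What is called first, only, known or untested is meant among the compounds shown, and "the series" means these compounds.

Measured in a functional assay on HT-29 cells (Homo sapiens) for antiproliferative activity, read by sulforhodamine B assay, with a stated time of 72 h; a lower number here means a stronger inhibitor, a higher number a weaker inhibitor:
- compound 1 `Fc1ccccc1NC(=S)N/N=C/c1ccc2ccccc2n1`: > 100000 nM
- compound 2 `S=C(N/N=C/c1ccc2ccccc2n1)Nc1cccc(Br)c1`: 58900 nM
- compound 3 `Cc1ccccc1NC(=S)N/N=C/c1ccc2ccccc2n1`: 42300 nM

The entry for compound 1 is a limit of the assay, not a number. Within the data shown here, compound 3, at 42300 nM, sits within the scatter of compound 2, as a 1.4-fold lower number from compound 2 to compound 3 (0.14 log units; within the scatter) shows, and these are the only two numbers available.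

The unmeasured compound 4 `Fc1ccc(NC(=S)N/N=C/c2ccc3ccccc3n2)cc1` carries 4-fluorophenyl in place of 2-methylphenyl on an amide-type nitrogen.

Among the measured compounds shown here, two measured steps bear most directly on this change. The closest is an at least 2.3-fold lower number from compound 1 to compound 3 (0.37 log units; beyond the scatter), methyl in place of fluoro on an aromatic carbon, and compound 4 reverses that exchange, although its fluoro group belongs to a different named group. The exchange of aryl groups in an at least 1.6-fold lower number from compound 1 to compound 2 (0.22 log units; that floor lies within the scatter) is a floor only. A modest step towards a higher number in this assay is therefore expected, and a result reported only as a limit remains possible.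

For compound 4 the estimated value is 65000 nM, with an expected range of 28000 nM to 100000 nM. This estimate means an expected 1.5-fold higher number from compound 3 to compound 4 (0.19 log units; within the scatter).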

Compound 4, half-maximal inhibitory concentration: 28500 nM
The estimate for compound 4 lay 2.3-fold (0.36 log units) above the measured number; low and high end bracket the measured number.
By their numbers in this assay, from the lowest: compounds 4, 3 and 2 (each within the scatter of the next, the first and the last beyond it). At a limit, above all of these: compound 1.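

In this assay, 4-fluorophenyl in place of 2-methylphenyl on the amide-type nitrogen gives a step within the scatter (a 1.5-fold lower number from compound 3 to compound 4 (0.17 log units; within the scatter)), so a fluoro-bearing phenyl group on this nitrogen need not end at a limit. Among these compounds, the two fluorophenyl groups, which the earlier compounds could not compare, are clearly apart (an at least 3.5-fold lower number from compound 1 to compound 4 (0.54 log units; beyond the scatter)), and 4-fluorophenyl also stands apart from 3-bromophenyl (a 2.1-fold lower number from compound 2 to compound 4 (0.32 log units; beyond the scatter)). Compound 1 remains a limit of the assay, which makes its step only a floor: the limit of > 100000 nM in this assay, at which 1 of the 4 values shown sits.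

The compounds shown leave open how 3-fluorophenyl or 4-methylphenyl would compare, and so whether the fluoro group or its place on the ring accounts for the gap. They also leave open how a methoxy group or an amine on this phenyl ring would read in this assay.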